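An indolyl group on the propyl chain of compound 1

A few compounds are considered here, and "the series" means these few. Any claim that something is new, unique, unknown or untested is made for them only; others in the source may bear on it.

In an ADME assay on AGS cells (Homo sapiens) for cytotoxicity, read by neutral red uptake, with a stated time of 24 h (a higher number here means a weaker inhibitor, a lower number a stronger inhibitor), compound 1 (`CCCC(=O)Oc1c(C(C)C)cc2c3c1OC(=O)[C@@]31CCCC(C)(C)[C@@H]1CC2`) gives 99500 nM and so stands lowest of the three compounds measured. Compound 2 (`CCCCC/C=C/C/C=C/CCCCCCCC(=O)Oc1c(C(C)C)cc2c3c1OC(=O)[C@@]31CCCC(C)(C)[C@@H]1CC2`) gives 253000 nM and compound 3 (`CC(C)c1cc2c3c(c1OC(=O)c1cccnc1)OC(=O)[C@@]31CCCC(C)(C)[C@@H]1CC2`) gives 280000 nM as close neighbours on the higher side. Compound 4 (`CC(C)c1cc2c3c(c1OC(=O)CCCc1c[nH]c4ccccc14)OC(=O)[C@@]31CCCC(C)(C)[C@@H]1CC2`) is compound 1 with its propyl group turned into 3-(1H-indol-3-yl)propyl (1H-indol-3-yl in place of hydrogen on a saturated chain carbon, three bonds along the chain from a carbonyl carbon). Among the compounds with values here, the one measured step bearing on this is a 2.8-fold higher number from compound 1 to compound 3 (0.45 log units; beyond the scatter) when pyridin-3-yl replaces propyl on a carbonyl carbon, and it is modest. The values of compound 2 and compound 3 show two different replacements of that propyl group both reading higher than compound 1. Within the data shown here, a change of similar size towards a higher number is therefore expected, though no measured compound carries an indole. In this assay the expected step is a 2.2-fold higher number from compound 1 to compound 4 (0.34 log units; beyond the scatter) on this reasoning. Compound 4 is expected at 220000 nM with 100000 nM to 450000 nM as its estimated range.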

Compound 4, half-maximal inhibitory concentration: 46800 nM
Compound 4: middle estimate off by 4.7-fold (0.67 log units), on the high side; the measured number lies below the stated range.
By their numbers in this assay, from the lowest: compound 4; then compound 1; then compounds 2 and 3 (each within the scatter of the next).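

In this assay, the group on the carbonyl carbon proves able to move the number in either direction: compound 1 had read lowest, yet a 2.1-fold lower number from compound 1 to compound 4 (0.33 log units; beyond the scatter) when 1H-indol-3-yl replaces hydrogen three bonds along the chain. Within the data shown here, the same position also gives a wider spread than the earlier compounds showed, with a 6.0-fold lower number from compound 3 to compound 4 (0.78 log units; beyond the scatter) when 3-(1H-indol-3-yl)propyl stands in place of pyridin-3-yl. Nothing available explains why the indole-bearing chain reads lower than the propyl group of compound 1.

The compounds shown leave open whether the lower number depends on the indole ring itself or would also appear with a phenyl ring or an amine at the end of the same chain. They also leave open how the shorter (1H-indol-3-yl)methyl and 2-(1H-indol-3-yl)ethyl groups would read.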